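The source may hold more compounds than are shown below. What is called first, only, known or untested is meant among the compounds shown, and "the series" means these compounds.

Of the compounds shown here, two built on a shared core have been measured in a functional assay on MCF7 cells (Homo sapiens) for cytotoxicity, read by MTT assay, with a stated time of 48 h; on this read-out lower numbers stand for stronger inhibition and higher numbers for weaker inhibition. Compound 1 `O=C(CSc1nnc(-c2ccncc2)o1)N/N=C/c1ccc(Cl)cc1` gives 15300 nM in this assay, the lower of the two numbers shown, though only within the scatter. Compound 2 `O=C(CSc1nnc(-c2ccncc2)o1)N/N=C/c1ccc(Br)cc1` gives 19100 nM, and the step of a 1.2-fold higher number from compound 1 to compound 2 (0.10 log units; within the scatter) shows how little a swap of one halogen for another moves the read-out. Compound 3 `O=C(CSc1nnc(-c2ccncc2)o1)N/N=C/c1cc(Cl)cc(Cl)c1O` has not yet been measured. It differs from compound 1 in one place: 3,5-dichloro-2-hydroxyphenyl in place of 4-chlorophenyl on a carbon with a double bond to nitrogen. For the measured compounds named here, the single measured step, bromo in place of chloro, bears only loosely on this change, which brings in a hydroxy group and a hydrogen-bond donor the measured pair knows nothing about. The expectation therefore rests on compound 1 alone and carries a wide range. Compound 3 is estimated at 10000 nM, between 3000 nM and 40000 nM. That would be an expected step of a 1.5-fold lower number from compound 1 to compound 3 (0.18 log units; within the scatter), likely no clearer than the scatter.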

Compound 3, half-maximal inhibitory concentration: 5920 nM
Compound 3: the middle estimate sits 1.7-fold (0.23 log units) above what was measured; the range from low to high includes it.
By their numbers in this assay, from the lowest: compound 3; then compounds 1 and 2 (each within the scatter of the next).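

For the compounds shown here, at the group on the carbon with a double bond to nitrogen, swapping one halogen for another had stayed within the scatter, but 3,5-dichloro-2-hydroxyphenyl in place of 4-chlorophenyl gives a 2.6-fold lower number from compound 1 to compound 3 (0.41 log units; beyond the scatter) in this assay, the first step here beyond the scatter. Measured against the bromo compound, the same group gives a 3.2-fold lower number from compound 2 to compound 3 (0.51 log units; beyond the scatter), also modest, so the read-out does respond to a change at this position. This change adds a hydroxy group and alters the chlorine pattern together, and nothing available explains the lower number.

The compounds shown leave open which of these two alterations carries the step, a question that 2-hydroxyphenyl alone or 3,5-dichlorophenyl alone could separate. Also open, on these data alone, is how the read-out would respond to an amine or a carboxylic acid on this ring.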